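This account rests on a few compounds, and the source may have more. Where it says the series, first, only, none or still open, it means among the compounds named here.

Among the compounds with values here, compound 2 `CCC(C(=O)N1CCN(c2cccc(C(F)(F)F)c2)CC1)N1C(=O)CCC1=O` stands highest of the two numbers so far in a functional assay on the whole organism (strain Swiss) with Mus musculus as the target, in the maximal electroshock model, with a stated time of 0.5 h, at a dose of 100 mg/kg by the intraperitoneal route; on this read-out higher numbers stand for a stronger effect at the one dose given and lower numbers for a weaker effect; in this assay compound 2 gives 50%, whereas compound 1 `CCC(C(=O)N1CCN(c2cccc(F)c2)CC1)N1C(=O)CCC1=O` gives 0%. Within the data shown here, the one measured step, a number 50 percentage points higher from compound 1 to compound 2 (beyond the scatter), is large. Compound 3 `CCC(C(=O)N1CCN(c2cccc(C)c2)CC1)N1C(=O)CCC1=O` differs from compound 2 by methyl in place of trifluoromethyl on an aromatic carbon. Among the measured compounds shown here, no measured step removes the trifluoromethyl, so the direction is inferred only from compound 2 holding the higher number against compound 1 with its 0%. A downward step is expected, a number 25 percentage points lower from compound 2 to compound 3 (beyond the scatter), with wide uncertainty. Compound 3 is therefore estimated at 25%, within 0% to 60%.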

Compound 3, a percentage reported as activity, at one dose (the size of the read-out at that dose, not a potency): 0%
Compound 3: the middle estimate sits 25 percentage points above what was measured, within the range that was stated.
By their numbers in this assay, from the lowest: compounds 1 and 3 (each within the scatter of the next); then compound 2.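

Replacing trifluoromethyl with methyl gives a number 50 percentage points lower from compound 2 to compound 3 (beyond the scatter) in this assay, so the read-out falls with a second replacement group and not only with fluoro. Methyl and fluoro do not separate at this position, with no change at the digits printed from compound 1 to compound 3 (within the scatter) in the same assay. Of the three groups shown on this aromatic carbon, only trifluoromethyl goes with a read-out clear of the others, and nothing measured here bears on the reason.

On these data alone, how chloro, methoxy or a nitrile would read at this place stays open. Also open, as far as these compounds go, is whether a longer chain such as ethyl would retain any of the read-out seen with trifluoromethyl.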